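Trimming the amide nitrogen of compound 3 to hydrogen

The compounds below may be only part of what the source reports. "The series", "measured", "known", "first", "only" and "open" are said of these compounds alone.

- compound 1 `Cc1n[nH]c2c1C(c1ccc(N(C)C)cc1)C(C(=O)NNC(N)=S)=C(N)N2`: 6260 nM
- compound 2 `Cc1n[nH]c2c1C(c1ccc(N(C)C)cc1)C(C(=O)n1ncc(C#N)c1N)=C(N)N2`: 60200 nM
- compound 3 `Cc1n[nH]c2c1C(c1ccc(N(C)C)cc1)C(C(=O)N/N=C/c1ccc(Cl)cc1)=C(N)N2`: 31700 nM

All three values come from a functional assay on HeLa cells (Homo sapiens) for cytotoxicity, read by MTT assay, with a stated time of 48 h (on this read-out higher numbers stand for weaker inhibition and lower numbers for stronger inhibition), and rest on the same core. Compound 3 cannot be told apart from compound 2 there, the gap being a 1.9-fold lower number from compound 2 to compound 3 (0.28 log units; within the scatter). Only the smallest number stands clear of the others, with a 5.1-fold higher number from compound 1 to compound 3 (0.70 log units; beyond the scatter) and a 9.6-fold higher number from compound 1 to compound 2 (0.98 log units; beyond the scatter).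

Compound 4 `Cc1n[nH]c2c1C(c1ccc(N(C)C)cc1)C(C(N)=O)=C(N)N2` is still unmeasured, and it differs from compound 3 by a hydrogen atom in place of a group of 9 heavy atoms (7 carbon, 1 nitrogen, 1 chlorine; one six-membered aromatic ring of carbon only), on an amide-type nitrogen. Among the compounds with values here, no measured step makes this exact change. The nearest evidence is the set of steps at the same side of the molecule, which are modest at most. Those steps give no direction for a bare hydrogen, so no step beyond the scatter is expected in this assay, though with wide uncertainty. The expected change is a 1.3-fold lower number from compound 3 to compound 4 (0.10 log units; within the scatter). For compound 4 the estimated value is 25000 nM, with an expected range from 7000 nM to 90000 nM.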

Compound 4, half-maximal inhibitory concentration: 5770 nM
Beside the measured number, compound 4's estimate is 4.3-fold (0.64 log units) above it; measured number below the stated range.
By their numbers in this assay, from the lowest: compounds 4 and 1 (each within the scatter of the next); then compounds 3 and 2 (each within the scatter of the next).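

In this assay, compound 4 shows that the amide-type nitrogen needs no ring-bearing group to reach the low end of this small series: hydrogen in place of the group carried by compound 3 gives a clear shift (a 5.5-fold lower number from compound 3 to compound 4 (0.74 log units; beyond the scatter)), and amino in place of 5-amino-4-cyano-1H-pyrazol-1-yl gives the largest step seen so far (a 10-fold lower number from compound 2 to compound 4 (1.02 log units; beyond the scatter)). The bare amide cannot be told apart from the sulfur-bearing, ring-free group of compound 1 (a 1.1-fold lower number from compound 1 to compound 4 (0.04 log units; within the scatter)), so among these four compounds, both ring-free members sit clear of both ring-bearing ones. No measurement shown here accounts for this result.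

From the compounds shown here alone, it remains open whether a methyl group or a short alkyl chain on that nitrogen would stay with compound 1 and compound 4. A carboxylic acid in place of the amide is equally unresolved.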